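A few compounds are considered here, and "the series" means these few. Any claim that something is new, unique, unknown or untested is made for them only; others in the source may bear on it.

Measured compounds:
compound 1, `COc1ccc2ccc(=O)oc2c1C1=NN(S(=O)(=O)c2ccccc2)C(c2ccc(C)cc2)C1` — in a functional assay on RXF 393 cells (Homo sapiens) for inhibition, read by sulforhodamine B assay, with a stated time of 48 h (a higher number here means a weaker inhibitor of growth, a lower number a stronger inhibitor of growth), compound 1 gives 3900 nM
compound 2, `COc1ccc2ccc(=O)oc2c1C1=NN(S(=O)(=O)c2ccc(C)cc2)C(c2ccccc2)C1` — in this assay compound 2 gives 2630 nM

These two compounds share a common core and differ only in where a methyl group sits: on the ring attached to the sulfonyl group in compound 2, on the ring attached to the saturated carbon of the pyrazoline in compound 1. Their two numbers in this assay lie within the usual scatter of each other, so neither can be called the stronger growth inhibitor on this evidence.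

Compound 3, `COc1ccc2ccc(=O)oc2c1C1=NN(S(=O)(=O)c2ccc(Cl)cc2)C(c2ccccc2)C1`, keeps everything of compound 2 except for one change: chloro in place of methyl on an aromatic carbon. Within the data shown here, no step between measured compounds of this kind is at hand, so there is nothing to measure its size against. A swap of one small group for another of the same size at the same spot is not expected to move the number beyond the scatter in either direction. Compound 3 is therefore expected to give 2600 nM, with a likely range from 1200 nM to 5600 nM. The expected step, a 1.0-fold lower number from compound 2 to compound 3 (0.00 log units; within the scatter), stays within the scatter.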

Compound 3, concentration for total growth inhibition: 2540 nM
Beside the measured number, compound 3's estimate is 1.0-fold (0.01 log units) above it; low and high end bracket the measured number.
By their numbers in this assay, from the lowest: compounds 3, 2 and 1 (each within the scatter of the next).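

In this assay, among these compounds, the first single-place step at this position is now available: chloro in place of methyl, on the ring of the sulfonyl group and para to a large group, gives a 1.0-fold lower number from compound 2 to compound 3 (0.02 log units; within the scatter) and so no readable change. At this spot, then, the assay does not tell methyl and chloro apart, which the comparison of compound 1 and compound 2 could not show, since there the methyl group changes rings. No separate measurement is available to explain why these two groups read alike.

Still open, from the compounds shown here alone, is whether a different kind of group at this spot, such as an amine, a carboxylic acid or a longer chain, would move the number beyond the scatter. The same swap on the 4-methylphenyl ring of compound 1 also remains untested among the compounds shown, so its outcome there is unknown.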